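The source may hold more compounds than are shown below. What is called first, only, known or untested is meant among the compounds shown, and "the series" means these compounds.

Compound 1 `COc1ccc(/C=C/C(=O)c2ccccc2-c2ccc(F)cc2)cc1`, in a functional assay on A549 cells (Homo sapiens) for antiproliferative activity, read by sulforhodamine B assay, with a stated time of 48 h; on this read-out lower numbers stand for stronger inhibition and higher numbers for weaker inhibition: 140 nM.
Compound 2 `COc1ccc(/C=C/C(=O)c2ccccc2-c2ccc(F)nc2)cc1`, in this assay: 930 nM.
Compound 3 `COc1ccc(C(=O)/C=C/c2ccccc2-c2ccc(F)cc2)cc1OC`, in this assay: 7500 nM.

Compound 2 differs from compound 1 in one place, (6-fluoropyridin-3-yl in place of 4-fluorophenyl on an aromatic carbon), and this change gave a 6.6-fold higher number from compound 1 to compound 2 (0.82 log units; beyond the scatter). Compound 3 is built on a different core, and the difference between the two cores is not broken down here; its value stands well apart from both compound 1 and compound 2. Compound 4 `COc1ccc(C(=O)/C=C/c2ccccc2-c2ccc(F)nc2)cc1OC` is compound 3 carrying the same change, (6-fluoropyridin-3-yl in place of 4-fluorophenyl on an aromatic carbon), at a place described in the same words. Compound 4 is expected to show a step of about the same size, a 6.0-fold higher number from compound 3 to compound 4 (0.78 log units; beyond the scatter), because the identical change once gave a 6.6-fold higher number from compound 1 to compound 2 (0.82 log units; beyond the scatter), though the different core adds uncertainty. Compound 4 is therefore estimated at 45000 nM in this assay, most likely between 15000 nM and 150000 nM.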

Compound 4, half-maximal inhibitory concentration: 17000 nM
For compound 4 the middle estimate is 2.6-fold (0.42 log units) above the measured one; the measured number falls inside the stated range.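

Putting 6-fluoropyridin-3-yl in place of 4-fluorophenyl again weakened activity in this assay, with a 2.3-fold higher number from compound 3 to compound 4 (0.36 log units; beyond the scatter). The direction of the change therefore carried over from one core to the other, but its size did not: the same change on two cores in this assay, a 6.6-fold higher number (0.82 log units; beyond the scatter) from compound 1 to compound 2 and a 2.3-fold higher number (0.36 log units; beyond the scatter) from compound 3 to compound 4, 2.9-fold (0.47 log units) apart, beyond the scatter of two such steps. Two cores cannot explain why the size differs, and they cannot show what the same change would do on a third core.

From the compounds shown here alone, the two cores differ in more than one place, and which of those differences matters remains open. Going by these compounds, it is also open how activity would respond if an amine or a carboxylic acid stood in place of the fluorine on either ring.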